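The source may report more compounds than this note shows. Statements on the series, on what has been measured and on what is new or still open speak of the compounds shown alone.

In an ADME assay on Huh7.5.1 cells (Homo sapiens) for cytotoxicity, read by ATP content, with a stated time of 48 h (a higher number here means that more compound is tolerated, a lower number that less compound is tolerated), compound 1 (`Cc1oc(-c2c(C)c(C)c(C)c(C)c2C)nc1CN1CCC(C(=O)NCCCN2C[C@H](C)C[C@H](C)C2)CC1`) gives 8180 nM. Compound 2 (`Cc1ccccc1-c1nc(CN2CCC(C(=O)NCCCN3CCC(C)(C)CC3)CC2)c(C)o1`) gives 10200 nM, within the scatter of compound 1, though the two differ in more than one place. Compound 3 (`Cc1oc(-c2c(Br)cccc2Br)nc1CN1CCC(C(=O)NCCCN2C[C@H](C)C[C@H](C)C2)CC1`) carries 2,6-dibromophenyl in place of the 2,3,4,5,6-pentamethylphenyl of compound 1 on an aromatic carbon: 2,6-dibromophenyl in place of 2,3,4,5,6-pentamethylphenyl on an aromatic carbon. Among the measured compounds shown here, no single-place step between measured compounds is available, so the expectation rests only on these two values. No change beyond the scatter is expected in this assay, with an estimated 1.2-fold higher number from compound 1 to compound 3 (0.09 log units; within the scatter). Compound 3 is expected at 10000 nM, with an estimated range of 4000 nM to 25000 nM.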

Compound 3, half-maximal cytotoxic concentration: 6500 nM
For compound 3 the middle estimate is 1.5-fold (0.19 log units) above the measured one, within the range that was stated.
By their numbers in this assay, from the lowest: compounds 3, 1 and 2 (each within the scatter of the next).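

In this assay, the single-place step at this position, on the aromatic carbon next to the ring nitrogen and next to the ring oxygen, is a 1.3-fold lower number from compound 1 to compound 3 (0.10 log units; within the scatter). With 2,6-dibromophenyl in place of 2,3,4,5,6-pentamethylphenyl, this exchange of one substituted aryl group for another therefore stays within the scatter. No measurement at hand bears on the reason for this.

As far as these compounds go, whether a carboxylic acid or an amine on this phenyl ring would shift the number beyond the scatter remains open. Also open, from the compounds shown here alone, is whether the same exchange would hold with the dimethylated amine of compound 2 in the side chain.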